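Removing the Methoxy Group from Compound 3

The compounds below may be only part of what the source reports. "The series", "measured", "known", "first", "only" and "open" are said of these compounds alone.

Among the measured compounds shown here, compound 3 `COc1cccc(/C=C/C(=O)c2sc(Nc3ccccc3)nc2C)c1` is the one compound of this set with a number in a functional assay on BGC-823 cells (Homo sapiens) for cytotoxicity, read by MTT assay (on this read-out higher numbers stand for weaker inhibition and lower numbers for stronger inhibition), where compound 3 gives 14300 nM. Compound 1 `COc1cccc(/C=C/C(=O)c2sc(Nc3cccc(C)c3)nc2C)c1` reaches only a limit of the assay, > 25000 nM. Compound 2 `COc1cccc(/C=C/C(=O)c2sc(Nc3ccc(Cl)cc3)nc2C)c1` likewise reaches only a limit, > 25000 nM. The two steps that lead to compound 3 both start from such limits: an at least 1.7-fold lower number from compound 1 to compound 3 (0.24 log units; that floor lies within the scatter) and an at least 1.7-fold lower number from compound 2 to compound 3 (0.24 log units; that floor lies within the scatter). Between the two limits the step cannot be read, a step that the two limits leave unreadable from compound 1 to compound 2, because of the limit of > 25000 nM in this assay, at which 2 of the 3 values shown sit. All three measured steps alter the group on the nitrogen; none touches the other ring of the shared core.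

Compound 4 `Cc1nc(Nc2ccccc2)sc1C(=O)/C=C/c1ccccc1` differs from compound 3 by hydrogen in place of methoxy on an aromatic carbon, that is, 3-methoxyphenyl becomes phenyl, on an aromatic carbon of a six-membered aromatic ring of carbon only, meta to a large group. For the measured compounds named here, no measured step covers this position, so the expectation rests on the narrow spread of the set, in which the only readable steps reach floors within the scatter. The step is therefore expected to stay within the scatter, a 1.4-fold higher number from compound 3 to compound 4 (0.15 log units; within the scatter). Compound 4 may well fall back to a limit. Compound 4 is estimated at 20000 nM, with a range from 8000 nM to 50000 nM.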

Compound 4, half-maximal inhibitory concentration: 19500 nM
For compound 4 the middle estimate is 1.0-fold (0.01 log units) above the measured one; the measured number falls inside the stated range.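

In this assay, among the compounds shown here, taking away the methoxy group gives a 1.4-fold higher number from compound 3 to compound 4 (0.13 log units; within the scatter), the first step in the set to be read between two numbers and the first to touch this aromatic carbon rather than the group on the nitrogen. With 3-methoxyphenyl replaced by phenyl, compound 4 still gives a measured number instead of a limit, so in this pair a number does not depend on the methoxy group. The pair therefore shows that, for this one replacement, the read-out does not separate methoxy from hydrogen at this place, although both numbers sit close to the point where the other compounds give only a limit: the limit of > 25000 nM in this assay, at which 2 of the 4 values shown sit.

Whether a hydroxyl, a chloro or an amine on this aromatic carbon would give a number that lies beyond the scatter remains open, since hydrogen is the only replacement for methoxy shown here. From the compounds shown here alone, it is also open how 3-methylphenyl or 4-chlorophenyl on the nitrogen would read alongside the unsubstituted phenyl of compound 4. The compounds carrying those groups all keep the methoxy group.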